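Dropping the Chloro from a Substance-P Receptor Urea

The source may report more compounds than this note shows. Statements on the series, on what has been measured and on what is new or still open speak of the compounds shown alone.

Compound 1 `CN(Cc1ccccc1Cl)C(=O)Nc1c(-c2ccc(F)cc2)c2ccccc2c(=O)n1C` is one of three ureas measured in an assay on IM-9 cells for binding affinity to Substance-P receptor (Homo sapiens); on this read-out lower numbers stand for stronger inhibition and higher numbers for weaker inhibition. Compound 1 gives 480 nM, the highest of the three numbers. Compound 2 `Cc1cc(C)cc(CN(C)C(=O)Nc2c(-c3ccccc3)c3cc(C)c(C)cc3c(=O)n2C)c1` gives 28 nM in this assay, and compound 3 `Cc1cc2c(-c3ccccc3)c(NC(=O)N(C)Cc3cc(C(F)(F)F)cc(C(F)(F)F)c3)n(C)c(=O)c2cc1C` gives 54 nM, each beyond the scatter below compound 1. Neither differs from compound 1 in one place only, so no single step can be read from them.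

Compound 4 `CN(Cc1ccccc1)C(=O)Nc1c(-c2ccc(F)cc2)c2ccccc2c(=O)n1C` differs from compound 1 by one change: hydrogen in place of chloro on an aromatic carbon. Nothing measured here isolates that change. The expected step of a 1.4-fold higher number from compound 1 to compound 4 (0.13 log units; within the scatter) is small, toward a slightly higher number, if beyond the scatter at all. Compound 4 is therefore estimated at 650 nM, within 200 nM to 2200 nM.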

Compound 4, half-maximal inhibitory concentration: 1500 nM
For compound 4 the middle estimate is 2.3-fold (0.36 log units) below the measured one, within the range that was stated.
By their numbers in this assay, from the lowest: compounds 2 and 3 (each within the scatter of the next); then compound 1; then compound 4.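

Going from 2-chlorobenzyl to benzyl gives a 3.1-fold higher number from compound 1 to compound 4 (0.49 log units; beyond the scatter) in this assay and provides the first reading of this position, where the chloro counts for a modest but real part of the binding number. Its loss moves the number in the weaker direction, beyond the scatter. Nothing available accounts for this step. As far as these compounds go, whether a fluoro, bromo, methyl or methoxy group on the same aromatic carbon would match chloro remains open. So does whether the step would be the same size on any other urea in this series.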